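Lengthening the Chain of Compound 2

The compounds below may be only part of what the source reports. "The series", "measured", "known", "first", "only" and "open" are said of these compounds alone.

In a functional assay on HeLa cells (Homo sapiens) for inhibition, read by MTT assay, with a stated time of 72 h (a higher number here means a weaker inhibitor, a lower number a stronger inhibitor), compound 2 `Nc1nc2cc(-c3nn(CCC(=O)NO)c4ncnc(N)c34)ccc2o1` reaches only a limit, > 150000 nM, and not a number. Going by these compounds, its true strength in these cells therefore stays unknown, and it gives no exact starting point for comparison.

Compound 3 `Nc1nc2cc(-c3nn(CCCCCCCCC(=O)NO)c4ncnc(N)c34)ccc2o1` keeps the rest of compound 2 and changes only the chain: 6-(hydroxycarbamoyl)hexyl in place of hydroxycarbamoyl on a saturated chain carbon, two bonds along the chain from an aromatic nitrogen. In words, this places 6-(hydroxycarbamoyl)hexyl in place of hydroxycarbamoyl on a saturated chain carbon, two bonds along the chain from an aromatic nitrogen. The hydroxycarbamoyl end is still there, but it now sits much farther out along the chain.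

Within the data shown here, no measured pair isolates this change, so the best guide is a single neighbouring compound. The longer chain also appears in compound 1 `Nc1ncnc2c1c(-c1cnc3[nH]ccc3c1)nn2CCCCCCCCC(=O)NO`, which gives 7470 nM in this assay, a measured number. On that basis, a large move toward stronger inhibition is expected, well beyond the usual scatter. The expected step is an at least 25-fold lower number from compound 2 to compound 3 (1.39 log units; beyond the scatter). For compound 3 the estimated value is 6000 nM, with an expected range of 1500 nM to 25000 nM.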

Compound 3, half-maximal inhibitory concentration: 10200 nM
Beside the measured number, compound 3's estimate is 1.7-fold (0.23 log units) below it, within the range that was stated.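

In this assay, the move to the longer chain on this saturated chain carbon gives an at least 14-fold lower number from compound 2 to compound 3 (1.16 log units; beyond the scatter), the first direct sign that replacing hydroxycarbamoyl with 6-(hydroxycarbamoyl)hexyl matters on this core. This step sets only a minimum size and not an exact one because compound 2 has a limit and not a number: the limit of > 150000 nM in this assay, at which 1 of the 3 values shown sits.

With the longer chain in place on both compounds, changing the group on the aromatic carbon gives a 1.4-fold higher number from compound 1 to compound 3 (0.14 log units; within the scatter), which is within the scatter, so this assay does not separate these two aromatic groups.

The compounds shown span only the short and long ends of the chain, so it remains open how strength changes at intermediate chain lengths or with a still longer chain. Among these compounds, it also remains open whether the hydroxycarbamoyl end is needed for the effect seen with the long chain, as no compound here carries a carboxylic acid or an amine at that end.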